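The source may report more compounds than this note shows. Statements on the series, on what has been measured and on what is new or still open speak of the compounds shown alone.

Working notes on the series. In a functional assay on HCC 2998 cells (Homo sapiens) for inhibition (a lower number here means a stronger inhibitor of growth, a higher number a weaker inhibitor of growth), compound 2 `Nc1ccc(-c2nc3ccc(F)cc3s2)cc1Cl` gives 90 nM, the lowest of the numbers to hand. Compound 3 `Cc1cc(-c2nc3cccc(F)c3s2)ccc1N` gives 13800 nM, a far higher number. Compound 1 `Cc1cc(-c2nc3c(F)cccc3s2)ccc1N` gives only a limit, > 100000 nM. Compound 4 `Cc1cc(-c2nc3ccc(F)cc3s2)ccc1N` is not yet measured in this assay. It has methyl in place of chloro on an aromatic carbon, ortho to an amino group: methyl in place of chloro on an aromatic carbon. For the measured compounds named here, no measured pair isolates this exchange, so no step beyond the scatter is expected, in either direction. The estimated 1.5-fold lower number from compound 2 to compound 4 (0.18 log units; within the scatter) is therefore small. The upper end stays wide since methyl-bearing compound 3 sits at 13800 nM. For compound 4 the expected value is 60 nM, with an estimated range of 3 nM to 1200 nM.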

Compound 4, concentration for 50% growth inhibition: 34700 nM
Compound 4: the middle estimate sits 580-fold (2.76 log units) below what was measured; the measured number lies above the stated range.
By their numbers in this assay, from the lowest: compound 2; then compound 3; then compound 4. At a limit, above all of these: compound 1.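

In this assay, the exchange of chloro for methyl, ortho to an amino group, gives a 390-fold higher number from compound 2 to compound 4 (2.59 log units; beyond the scatter). For the compounds shown here, this is the first isolated reading of this position, and it shows that a change of one heavy atom, with the rest of the structure held constant, is enough to separate these two compounds far beyond the scatter. Nothing measured here accounts for the size of this step. The compounds shown leave open whether bromo, a nitrile or a plain hydrogen at this position would behave like chloro or like methyl, and whether the same step holds when the fluoro sits elsewhere, as in compound 1 and compound 3.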